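From ethoxy to hydroxy on a shared core

The source may hold more compounds than are shown below. What is called first, only, known or untested is meant among the compounds shown, and "the series" means these compounds.

Measured in a functional assay on RAW264.7 cells (Mus musculus) for inhibition, read by Griess assay, with a stated time of 24 h (on this read-out higher numbers stand for weaker inhibition and lower numbers for stronger inhibition), so far:
Compound 1 `COc1cc(O)c(C(=O)/C=C/c2ccc(C)cc2)c(OC)c1` gives 6300 nM
Compound 2 `CCOc1cc(OC)cc(OC)c1C(=O)/C=C/c1cccc(OC)c1` gives 2700 nM

Compound 2 at 2700 nM stands lowest of the two numbers, and compound 1 lies above it by more than the usual scatter. Compound 3 `COc1cccc(/C=C/C(=O)c2c(O)cc(OC)cc2OC)c1` has not yet been measured. It carries hydrogen in place of ethyl on an oxygen on an aromatic ring, the change from ethoxy to hydroxy. Within the data shown here, no measured pair isolates this change. Compound 1 at 6300 nM also carries hydroxy but differs from compound 2 elsewhere too, so it offers only a weak hint toward a higher number. In this assay a small move in that direction is expected, with no step beyond the scatter. The estimated 1.3-fold higher number from compound 2 to compound 3 (0.11 log units; within the scatter) is expected to remain small. For compound 3 the expected value is 3500 nM with an estimated range from 1200 nM to 10000 nM as the likely span.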

Compound 3, half-maximal inhibitory concentration: 2400 nM
The estimate for compound 3 lay 1.5-fold (0.16 log units) above the measured number; the measured number falls inside the stated range.
By their numbers in this assay, from the lowest: compounds 3 and 2 (each within the scatter of the next); then compound 1.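

In this assay, hydrogen in place of ethyl on an oxygen on an aromatic ring gives a 1.1-fold lower number from compound 2 to compound 3 (0.05 log units; within the scatter), so the two compounds read alike. Among these compounds, this is the first pair that isolates the change from ethoxy to hydroxy, and it shows that, on this core, the ethyl group can be lost from this oxygen with no step beyond the scatter. Nothing shown gives a reason why the two compounds read alike.

From the compounds shown here alone, a longer chain on this oxygen, such as butyl, remains open, as does an amine or a carboxylic acid at this place. This single pair also leaves open whether the change from ethoxy to hydroxy would read the same way on a core carrying other groups elsewhere.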